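Methoxy in place of bromo on the shared core

The compounds below may be only part of what the source reports. "The series", "measured", "known", "first", "only" and "open" are said of these compounds alone.

Going by the values given here, compound 2 `C=CCc1ccc(OCc2cn(-c3ccc(Br)cc3)nn2)c(O)c1` stands, among the two numbers measured so far in a functional assay on SK-N-SH cells (Homo sapiens) for inhibition, read by MTT assay, with a stated time of 72 h, tested at 50 uM (a higher number here means more inhibition of growth at the concentration tested, a lower number less inhibition of growth), alongside compound 1 `C=CCc1ccc(OCc2cn(-c3ccc(C(=O)c4ccccc4)cc3)nn2)c(O)c1`; in this assay compound 2 gives 61.7% and compound 1 gives 58.1%, and the step of a number 3.6 percentage points higher from compound 1 to compound 2 (within the scatter) lies within the scatter, so neither can be set above the other.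

Compound 3 `C=CCc1ccc(OCc2cn(-c3ccc(OC)cc3)nn2)c(O)c1` differs from compound 2 by methoxy in place of bromo on an aromatic carbon. Among the compounds with values here, the only measured step that bears on an exchange at this place, bromo in place of benzoyl on an aromatic carbon, was a number 3.6 percentage points higher from compound 1 to compound 2 (within the scatter), within the scatter. With one such step, and that one flat, no shift beyond the scatter is expected in this assay from a further exchange at the same place. For compound 3 the step expected in this assay is a number 3.7 percentage points lower from compound 2 to compound 3 (within the scatter), not beyond the scatter. Compound 3 is therefore estimated at 58%, with a range from 45% to 70%.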

Compound 3, percent growth inhibition at one concentration: 68.5%
For compound 3 the middle estimate is 10.5 percentage points below the measured one, and the stated range covers the measured number.
By their numbers in this assay, from the lowest: compounds 1, 2 and 3 (each within the scatter of the next, the first and the last beyond it).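

Going by these compounds alone, at this place, para to a large group, the exchanges are no longer all flat: methoxy in place of benzoyl gives the first step beyond the scatter in this assay, a number 10.4 percentage points higher from compound 1 to compound 3 (beyond the scatter), though only a modest one. Methoxy in place of bromo stays inside that scatter, a number 6.8 percentage points higher from compound 2 to compound 3 (within the scatter), so only the benzoyl and methoxy ends of the series can be told apart, and compound 2 cannot be separated from either. Nothing available gives a cause for these numbers.

As far as these compounds go, whether an amine, a carboxylic acid or a longer alkoxy chain at this place would carry the number clear of the methoxy result remains open. So does whether the step from benzoyl to methoxy would hold with any other change on the shared core.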